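Swapping an aryl amide for a pyridylmethyl amide

The compounds below may be only part of what the source reports. "The series", "measured", "known", "first", "only" and "open" are said of these compounds alone.

Measured so far:
Compound 1 `COc1cc(-c2cc(C(=O)O)c3ccccc3n2)ccc1OCC(=O)Nc1cccc(F)c1` gives 148000 nM in an ADME assay on HaCaT cells (Homo sapiens) for inhibition; a lower number here means a stronger inhibitor, a higher number a weaker inhibitor.
Compound 2 `COc1cc(-c2cc(C(=O)O)c3ccccc3n2)ccc1OCC(=O)Nc1ccccc1Cl` gives 210000 nM in this assay.
Compound 3 `COc1cc(-c2cc(C(=O)O)c3ccccc3n2)ccc1OCC(=O)Nc1ccccc1C(F)(F)F` gives 102000 nM in this assay.

All three compounds share one core and differ only in the ring attached to the amide-type nitrogen. Compound 3 has the lowest number of the three in this assay, though its closeness to compound 1 is shown by a 1.5-fold lower number from compound 1 to compound 3 (0.16 log units; within the scatter), while the larger gap is shown by a 2.1-fold lower number from compound 2 to compound 3 (0.31 log units; beyond the scatter). The other pair gives a 1.4-fold higher number from compound 1 to compound 2 (0.15 log units; within the scatter).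

Compound 4 `COc1cc(-c2cc(C(=O)O)c3ccccc3n2)ccc1OCC(=O)NCc1cccnc1` has not been measured yet. It differs from compound 3 in this way: (pyridin-3-yl)methyl in place of 2-(trifluoromethyl)phenyl on an amide-type nitrogen. Within the data shown here, none of the measured steps touches this kind of change; each of them kept a phenyl ring directly on the nitrogen and only exchanged a small group on that ring, and even then the largest of them was modest, as a 2.1-fold lower number from compound 2 to compound 3 (0.31 log units; beyond the scatter) shows. With nothing else to lean on, the expectation for compound 4 is a number close to those of the three measured compounds, with the step of a 1.5-fold higher number from compound 3 to compound 4 (0.17 log units; within the scatter) likely staying within the scatter. Compound 4 is therefore expected to give about 150000 nM, estimated between 60000 nM and 400000 nM.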

Compound 4, half-maximal inhibitory concentration: > 300000 nM
Compound 4 gave a limit, no number; the forecaster's own chance of this, stated with the estimate: 20%; middle value at least 2.0-fold (0.30 log units) away from the limit.
By their numbers in this assay, from the lowest: compounds 3, 1 and 2 (each within the scatter of the next, the first and the last beyond it). At a limit, above all of these: compound 4.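

In this assay compound 4 gives a limit of the assay and not a number: the limit of > 300000 nM in this assay, at which 1 of the 4 values shown sits.
Replacing a phenyl ring set directly on the amide-type nitrogen with (pyridin-3-yl)methyl is a larger kind of change than the exchanges of a small group on that ring, and its step from the lowest-numbered compound already exceeds every step among the first three compounds (an at least 2.9-fold higher number from compound 3 to compound 4 (0.46 log units; beyond the scatter)). The floors of the steps from the other two compounds are smaller (an at least 1.4-fold higher number from compound 2 to compound 4 (0.15 log units; that floor lies within the scatter); an at least 2.0-fold higher number from compound 1 to compound 4 (0.30 log units; that floor lies within the scatter)), so the separation is firmly established only from compound 3.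

This change alters the ring and also places a methylene chain unit between that ring and the amide-type nitrogen, so the compounds shown cannot say which alteration matters, and neither can they say how far the true value of compound 4 lies beyond its limit. A benzyl group on that nitrogen, which keeps the methylene but has an all-carbon ring, or a pyridin-3-yl ring attached directly to it, would pull these two alterations apart.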